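Phenoxy-acetyl series: aryl swap from compound 1 to compound 4

The source may report more compounds than this note shows. Statements on the series, on what has been measured and on what is new or still open speak of the compounds shown alone.

Measured so far:
compound 1 `Cc1ccc(OCC(=O)N2CCN(c3ccc(C(F)(F)F)cc3[C@@H](N)CC(C)C)CC2)cc1` — 4400 nM
compound 2 `CC(C)C[C@H](N)c1cc(F)ccc1N1CCN(C(=O)C(C)Cc2ccc(Cl)cc2)CC1` — 390 nM
compound 3 `COc1cc(Cl)ccc1C[C@@H](C)C(=O)N1CCN(c2ccc(C)cc2[C@@H](N)CC(C)C)CC1` — 8.1 nM

In an assay on HEK293 cells for displacement of a labelled ligand from Melanocortin receptor 4 (Homo sapiens) (on this read-out lower numbers stand for stronger inhibition and higher numbers for weaker inhibition), compound 1 gives 4400 nM, the highest number of the three. Compound 2 sits at 390 nM, a gap beyond the scatter, and compound 3 at 8.1 nM, further still. Going by the values given here, compounds 2 and 3 differ from compound 1 in more than one place, so no single step between them can be read.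

Compound 4 `CC(C)C[C@H](N)c1cc(C(F)(F)F)ccc1N1CCN(C(=O)COc2cccc(Cl)c2)CC1` is the next entry. Relative to compound 1 the change is 3-chlorophenyl in place of 4-methylphenyl on an oxygen on a saturated carbon. The rest of the molecule, including the trifluoromethyl on the shared core, is kept. The change is confined to the aryl group: 3-chlorophenyl in place of 4-methylphenyl, read one bond further out as 4-methylphenoxy to 3-chlorophenoxy. Among the compounds with values here, no measured pair isolates this swap. The expectation for compound 4 is a modest improvement, a step of a 1.8-fold lower number from compound 1 to compound 4 (0.25 log units; within the scatter) in this assay, close to the edge of the scatter rather than clearly beyond it. The estimate for compound 4 is 2500 nM, with a range from 800 nM to 8000 nM.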

Compound 4, inhibition constant: 2600 nM
Compound 4: middle estimate off by 1.0-fold (0.02 log units), on the low side; the measured number falls inside the stated range.
By their numbers in this assay, from the lowest: compound 3; then compound 2; then compounds 4 and 1 (each within the scatter of the next).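

In this assay, the series gets its first single-place reading, with a step of a 1.7-fold lower number from compound 1 to compound 4 (0.23 log units; within the scatter) for 3-chlorophenyl in place of 4-methylphenyl on an oxygen on a saturated carbon. At this place, then, the two aryl groups cannot be told apart in this read-out, although the swap alters both the ring substituent and its printed location. No accompanying measurement speaks to this result.

From the compounds shown here alone, the swap changes two things at once, so it remains open whether each change alone would also leave the number within the scatter, a question that 4-chlorophenyl and 3-methylphenyl would separate. Also open, going by these compounds, is whether this place responds to a different kind of group, such as a nitrile or an amine on the ring, or to a longer chain in place of the (aryloxy)methyl link.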